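Enlarging the hydroxylated ring of compound 2

The source may hold more compounds than are shown below. What is called first, only, known or untested is meant among the compounds shown, and "the series" means these compounds.

In an ADME assay on S9 fraction from liver (Homo sapiens) for metabolic stability, with a stated time of 1 h (on this read-out higher numbers stand for a more stable compound and lower numbers for a less stable compound), compound 2 `N#Cc1cnc(NCc2cnccc2C(F)(F)F)cc1NC[C@H]1C[C@@H](O)C1` gives 84%. That is within the scatter of compound 1 `N#Cc1cnc(NCc2cnccc2C(F)(F)F)cc1N[C@H]1C[C@@H](O)C1` at 90%. Compound 3 `N#Cc1cnc(NCc2ccccc2C(F)(F)F)cc1N[C@H]1CC[C@@H](O)CC1` gives 0%, and its gap to compound 2 is far larger than the usual scatter.

Compound 4 `N#Cc1cnc(NCc2cnccc2C(F)(F)F)cc1NC[C@H]1CC[C@@H](O)CC1` differs from compound 2 by a single change: 4-hydroxycyclohexyl in place of 3-hydroxycyclobutyl on a saturated chain carbon bound to a nitrogen on an aromatic ring. Put simply, 4-hydroxycyclohexyl stands in place of 3-hydroxycyclobutyl on a saturated chain carbon bound to a nitrogen on an aromatic ring.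

Within the data shown here, only one measured step differs in a single place, a number 6 percentage points lower from compound 1 to compound 2 (within the scatter). It stayed within the scatter, but it concerns the chain rather than the ring, so it says little here. Among the measured compounds shown here, the closer clue is compound 3 at 0%, the only measured compound carrying 4-hydroxycyclohexyl. It differs from compound 2 in more than one place, however, so its low number cannot be tied to that group alone.

A partial fall is therefore expected, with an estimated a number 29 percentage points lower from compound 2 to compound 4 (beyond the scatter). For compound 4 the estimated value is 55%, with an expected range of 20% to 85%.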

Compound 4, percent of the compound remaining: 41%
Beside the measured number, compound 4's estimate is 14 percentage points above it; the range from low to high includes it.
By their numbers in this assay, from the lowest: compound 3; then compound 4; then compounds 2 and 1 (each within the scatter of the next).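

In this assay, replacing 3-hydroxycyclobutyl with 4-hydroxycyclohexyl on the same saturated chain carbon gives a number 43 percentage points lower from compound 2 to compound 4 (beyond the scatter) and so isolates the ring swap, which compound 3 could not do because it differs from compound 2 in more than one place. The wider comparison gives a number 49 percentage points lower from compound 1 to compound 4 (beyond the scatter), whereas adding only the chain carbon to the four-membered ring gives a number 6 percentage points lower from compound 1 to compound 2 (within the scatter), so among these compounds the large loss appears only with the six-membered ring. Nothing available explains why stability falls with this ring.

The compounds shown leave open whether the loss builds gradually with ring size, which a 3-hydroxycyclopentyl group on the same chain carbon could test. They also leave open whether the hydroxyl matters to the loss, which an amine in its place on the six-membered ring could help to show.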